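This account rests on a few compounds, and the source may have more. Where it says the series, first, only, none or still open, it means among the compounds named here.

Working notes on the series.

The three measured compounds share a core and carry differing amine substituents and amide-linked side chains. Compound 1 `C=CCNc1nc(NCc2ccc(C(=O)Nc3ccc(F)cc3)cc2)c2ccccc2n1` and compound 2 `Cc1ccc2nc(N(C)C)nc(NCc3ccc(C(=O)NCc4ccc(F)cc4)cc3)c2c1` are joined by compound 3 `CN(C)c1nc(NCc2ccc(NC(=O)c3ccncc3)cc2)c2ccccc2n1`. In a functional assay on HCT-116 cells (Homo sapiens) for inhibition, read by luminescence and resazurin assay, with a stated time of 3 days (a higher number here means a weaker inhibitor, a lower number a stronger inhibitor), compound 1 gives 14000 nM, compound 2 gives 900 nM, and compound 3 gives 15000 nM. Compound 3 has the highest of the three numbers; its value and that of compound 1 lie within the scatter of each other, so no order is claimed between them, while compound 2 sits well below compound 3, beyond the scatter.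

The next compound to be tested is compound 4 `CN1CCN(c2nc(NCc3ccc(NC(=O)c4ccncc4)cc3)c3ccccc3n2)CC1`. It keeps the amide-linked side chain of compound 3 and differs only at the amine: 4-methylpiperazin-1-yl in place of dimethylamino on an aromatic carbon. Among the compounds with values here, no measured pair in this set isolates such a change, so the direction of the step cannot be read from the data. The number for compound 4 is expected to move little, with a step from compound 3 to compound 4 of about a 1.7-fold lower number from compound 3 to compound 4 (0.22 log units; within the scatter) toward a lower value, which may not exceed the scatter. Compound 4 is estimated at 9000 nM in this assay, within a range from 3000 nM to 27000 nM.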

Compound 4, half-maximal inhibitory concentration: > 20000 nM
Compound 4 was reported as a limit; the forecaster's own chance of this, stated with the estimate: 5%; middle value at least 2.2-fold (0.34 log units) away from the limit.
By their numbers in this assay, from the lowest: compound 2; then compounds 1 and 3 (each within the scatter of the next). At a limit, above all of these: compound 4.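

Within the data shown here, this is the first measured step at the aromatic carbon between two ring nitrogen atoms: 4-methylpiperazin-1-yl in place of dimethylamino gives an at least 1.3-fold higher number from compound 3 to compound 4 (0.12 log units; that floor lies within the scatter) in this assay. Compound 4 is reported only as a limit, so this step is a floor and its full size cannot be read: the limit of > 20000 nM in this assay, at which 1 of the 4 values shown sits. Among these compounds, with the side chain held constant, the 4-methylpiperazin-1-yl group brings no lowering of the number at this position, something no earlier pair could show.

On these data alone, whether a morpholin-4-yl group or a plain amino group on this carbon would give a lower number remains open. Also open, as far as these compounds go, is whether the same replacement would act in the same way with the side chain and core of compound 2.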